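The compounds below may be only part of what the source reports. "The series", "measured", "known", "first", "only" and "open" are said of these compounds alone.

Compound 1, `CC1=C(C(=O)CC(C)C)C(c2ccsc2)NC(=O)N1`, gives 14% in an assay on membranes from HeLa cells for displacement of a labelled ligand from adenosine receptor A3 (Homo sapiens), read by scintillation counting, with a stated time of 180 min, tested at 1 uM; a higher number here means more inhibition at the concentration tested (going by the name of the read-out), a lower number less inhibition.
Compound 2, `CC1=C(C(N)=O)C(c2ccsc2)NC(=O)N1`, gives 1% in this assay.
Compound 3, `CCN(CC)C(=O)C1=C(C)NC(=O)NC1c1ccsc1`, gives 35% in this assay.

Of these three, compound 3 stands highest in this assay, and both gaps to it lie beyond the scatter: a number 21 percentage points higher from compound 1 to compound 3 (beyond the scatter) and a number 34 percentage points higher from compound 2 to compound 3 (beyond the scatter). All three compounds share one core and differ only in the group on the carbonyl carbon attached to it, so every measured step speaks to that single position.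

Compound 4, `CCSC(=O)C1=C(C)NC(=O)NC1c1ccsc1`, is not yet measured. It differs from compound 3 in one place: ethylsulfanyl in place of diethylamino on a carbonyl carbon. The three measured steps that bear on this are a number 13 percentage points lower from compound 1 to compound 2 (beyond the scatter), a number 21 percentage points higher from compound 1 to compound 3 (beyond the scatter) and a number 34 percentage points higher from compound 2 to compound 3 (beyond the scatter): changing the group on this carbonyl carbon has moved the number by a modest to large amount each time, in both directions. For the measured compounds named here, the ethylsulfanyl group is new here, so its direction cannot be read from a matching step; the numbers show only that the diethylamino group of compound 3 is the highest point seen, and two of three alternatives sit well below it.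

Compound 4 is therefore expected to give about 18%, with a range from 3% to 38%. The expected step is a number 17 percentage points lower from compound 3 to compound 4 (beyond the scatter), a downward move beyond the scatter.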

Compound 4, a percentage reported as inhibition, at one concentration (the size of the read-out at that concentration, not a potency): 2%
For compound 4 the middle estimate is 16 percentage points above the measured one, outside the stated range (below it).
By their numbers in this assay, from the lowest: compounds 2 and 4 (each within the scatter of the next); then compound 1; then compound 3.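

In this assay, ethylsulfanyl on this carbonyl carbon gives a number 33 percentage points lower from compound 3 to compound 4 (beyond the scatter), so the highest number seen so far does not carry over to this new group, which has a sulfur in place of the nitrogen that joins diethylamino to the carbonyl carbon. The new group also lands level with the amino group of compound 2, with a number 1 percentage points higher from compound 2 to compound 4 (within the scatter), and under the isobutyl group, with a number 12 percentage points lower from compound 1 to compound 4 (beyond the scatter), which leaves diethylamino alone at the top of the four groups tried at this position. No measurement here explains why the number falls with this change.

The step from diethylamino to ethylsulfanyl changes both the atom joined to the carbonyl carbon and the number of heavy atoms in the group, so these compounds cannot show which of the two matters. An ethylamino group, which keeps the nitrogen and has a single ethyl chain, or a dipropylamino group, which has longer chains on the nitrogen, would be the natural groups for separating these two changes.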